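Hydroxy for methyl on the acyl ring of compound 2

The source may report more compounds than this note shows. Statements on the series, on what has been measured and on what is new or still open speak of the compounds shown alone.

Measured compounds:
compound 1 `Cc1c(OCCCCOc2ccc(C(=O)CC(C)(C)C)c(O)c2C)cccc1C(=O)O`, 136 nM
compound 2 `Cc1c(OCCCCOc2cccc(C(=O)O)c2)ccc(C(=O)CC(C)C)c1C`, "not active" (no number reported)
compound 3 `Cc1c(OCCCCOc2ccccc2C(=O)O)ccc(C(=O)CC2CCCC2)c1O`, 335 nM

In an assay on HEK293 cells for positive allosteric modulation of metabotropic glutamate receptor 2 (Rattus norvegicus), read by thallium flux, with a stated time of 2.5 min (a lower number here means that less compound is needed, a higher number that more compound is needed for the effect), compound 1 gives 136 nM and compound 3 gives 335 nM; both carry a hydroxy group on the ring that bears the ketone. Compound 2 stands apart: in this assay compound 2 is reported as "not active" (no number reported), with no single number, so it cannot be placed on the scale alongside compound 1 and compound 3.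

Compound 4 `Cc1c(OCCCCOc2cccc(C(=O)O)c2)ccc(C(=O)CC(C)C)c1O` is not yet measured. It differs from compound 2 in one place: hydroxy in place of methyl on an aromatic carbon. The hydroxy enters ortho to the isobutylcarbonyl group, where compound 1 and compound 3 also carry a hydroxy.

Going by the values given here, no measured step joins these compounds. Among the compounds with values here, since compound 2 has no number, no step size can be stated for this assay; the expectation is only that compound 4 returns a measurable value rather than an inactive call, in the neighbourhood of compound 1 and compound 3. Compound 4 is therefore expected to give about 400 nM, within 120 nM to 1500 nM.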

Compound 4, half-maximal effective concentration: 222 nM
Estimate against measurement, compound 4: 1.8-fold (0.26 log units) above, and the stated range covers the measured number.
By their numbers in this assay, from the lowest: compounds 1, 4 and 3 (each within the scatter of the next, the first and the last beyond it).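

In this assay, going by these compounds alone, compound 2 is reported as "not active" (no number reported) and compound 4 gives 222 nM so no step between compound 2 and compound 4 can be read. The compounds shown leave open what the isobutylcarbonyl group alone contributes to the value. No measurement here accounts for the result.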